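Triazole carboxamide EP4 antagonists: para substituent on the benzyl

The source may report more compounds than this note shows. Statements on the series, on what has been measured and on what is new or still open speak of the compounds shown alone.

Measured compounds:
compound 1 `C[C@H](NC(=O)c1nnn(Cc2ccc(F)cc2)c1C(F)(F)F)c1ccc(C(=O)O)cc1`, > 10000 nM
compound 2 `C[C@H](NC(=O)c1nnn(Cc2ccc(C(F)(F)F)cc2)c1-c1ccccc1)c1ccc(C(=O)O)cc1`, > 10000 nM
compound 3 `C[C@H](NC(=O)c1c(-c2ccccc2)nnn1Cc1ccc(F)c(F)c1)c1ccc(C(=O)O)cc1`, 148 nM

For the measured compounds named here, in a functional assay on CHO cells for antagonist activity at prostaglandin E2 receptor EP4 subtype (Homo sapiens), read by calcium flux, with a stated time of 15 min (a lower number here means a stronger inhibitor, a higher number a weaker inhibitor), compound 3 gives 148 nM, the only numerical value so far. Compound 1 sits at a limit of this assay, > 10000 nM. Compound 2 likewise sits at a limit, > 10000 nM. Going by the values given here, the limit of > 10000 nM in this assay, at which 2 of the 3 values shown sit, is a boundary of the assay and not a number, so no step between measured compounds can be sized here; compounds 1 and 2 differ from compound 3 in more than one place each, and only their limit values can be stated.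

Compound 4 `COc1ccc(Cn2nnc(-c3ccccc3)c2C(=O)N[C@@H](C)c2ccc(C(=O)O)cc2)cc1F` is not yet measured. It keeps the phenyl on the core and the fluoro pattern of compound 3 apart from one change: methoxy in place of fluoro on an aromatic carbon, ortho to a fluoro group and para to a large group, so that 3,4-difluorobenzyl becomes 3-fluoro-4-methoxybenzyl.

Among the compounds with values here, no measured step of this kind exists. The expectation for compound 4 is a modest weakening, with a step of a 1.9-fold higher number from compound 3 to compound 4 (0.28 log units; within the scatter) that may well lie within the scatter. Compound 4 is therefore estimated at 280 nM, in the range 70 nM to 1500 nM.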

Compound 4, half-maximal inhibitory concentration: 29.8 nM
For compound 4 the middle estimate is 9.4-fold (0.97 log units) above the measured one; measured number below the stated range.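

In this assay, for the compounds shown here, methoxy in place of fluoro on an aromatic carbon, ortho to a fluoro group and para to a large group, gives a 5.0-fold lower number from compound 3 to compound 4 (0.70 log units; beyond the scatter), the only step that can be sized so far. The position is therefore not confined to a single fluorine: it takes methoxy, with 2 heavy atoms and 1 hydrogen-bond acceptor, and the number falls rather than rises, with the neighbouring fluoro and the phenyl on the core unchanged. No step to compound 1 or compound 2 can be read, and neither compound says anything about this change, as each differs from compound 3 and compound 4 in more than one place and carries only a limit of the assay: the limit of > 10000 nM in this assay, at which 2 of the 4 values shown sit.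

This single step cannot separate the contribution of the oxygen from that of the added carbon, and the data give no cause for the lower number. On these data alone, whether an ethoxy group, a hydroxyl group or an amine in the same place would keep the gain stays open, as does whether methoxy would give it without the neighbouring fluoro.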